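Thiazole substituent swap, vinyl to cyano, cytotoxicity series

The source may report more compounds than this note shows. Statements on the series, on what has been measured and on what is new or still open speak of the compounds shown alone.

Of the compounds shown here, two carry a measured number so far. Compound 1 `COc1ccc2c(O[C@H]3C[C@H]4C(=O)N(C)CCCC/C=C/[C@@H]5C[C@@]5(C(=O)NS(=O)(=O)C5(C)CC5)NC(=O)N4C3)cc(-c3csc(C(C)C)n3)nc2c1Cl` is one of them; in an ADME assay on Huh-7 cells (Homo sapiens) for cytotoxicity, read by colorimetric assay (a higher number here means that more compound is tolerated, a lower number that less compound is tolerated), compound 1 gives 30200 nM. Compound 2 `C=Cc1csc(-c2cc(O[C@H]3C[C@H]4C(=O)N(C)CCCC/C=C/[C@@H]5C[C@@]5(C(=O)NS(=O)(=O)C5(C)CC5)NC(=O)N4C3)c3ccc(OC)c(Cl)c3n2)n1` is the other; in this assay compound 2 gives 57100 nM. Within the data shown here, the single step between them, a 1.9-fold higher number from compound 1 to compound 2 (0.28 log units; within the scatter), rearranges the thiazole substitution and stays within the scatter. Among the measured compounds shown here, on these two numbers compound 2 cannot be told apart from compound 1, which is its only neighbour.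

Compound 3 `COc1ccc2c(O[C@H]3C[C@H]4C(=O)N(C)CCCC/C=C/[C@@H]5C[C@@]5(C(=O)NS(=O)(=O)C5(C)CC5)NC(=O)N4C3)cc(-c3nc(C#N)cs3)nc2c1Cl` is not yet measured. Relative to compound 2 the change is cyano in place of vinyl on an aromatic carbon. For the measured compounds named here, the only measured step that touches the same thiazole, a 1.9-fold higher number from compound 1 to compound 2 (0.28 log units; within the scatter), did not move the number beyond the scatter, and no step yet shows a cyano in this place. The working expectation for this assay is therefore no step beyond the scatter, in either direction. Compound 3 is expected to give 45000 nM in this assay, with a range from 18000 nM to 110000 nM, which amounts to an expected 1.3-fold lower number from compound 2 to compound 3 (0.10 log units; within the scatter).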

Compound 3, half-maximal cytotoxic concentration: 75000 nM
The estimate for compound 3 lay 1.7-fold (0.22 log units) below the measured number; the range from low to high includes it.
By their numbers in this assay, from the lowest: compounds 1, 2 and 3 (each within the scatter of the next, the first and the last beyond it).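

In this assay, a group with one hydrogen-bond acceptor, cyano, stands in place of vinyl, which has none, on the thiazole carbon next to the ring nitrogen, and the two compounds are not separated: a 1.3-fold higher number from compound 2 to compound 3 (0.12 log units; within the scatter). Among these compounds, the wider replacement, 4-cyano-1,3-thiazol-2-yl in place of 2-isopropyl-1,3-thiazol-4-yl, gives the only step beyond the scatter, a modest one: a 2.5-fold higher number from compound 1 to compound 3 (0.40 log units; beyond the scatter). Compound 2 lies within the scatter of both neighbours, so the vinyl and cyano compounds cannot be ranked against each other, and nothing measured here accounts for the difference between the isopropyl and cyano compounds.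

From the compounds shown here alone, it remains open whether that modest step follows the group on the thiazole or the change from the 4-yl to the 2-yl attachment, as the two compounds differ in both within that one replacement. Also open, going by these compounds, is whether an amine, a carboxylic acid or a longer chain on the same thiazole carbon would stay within the scatter of compound 2 and compound 3 in this assay.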